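Changing the sulfonyl ring of compound 1

This account rests on a few compounds, and the source may have more. Where it says the series, first, only, none or still open, it means among the compounds named here.

Measured in an ADME assay on HepG2 cells (Homo sapiens) for cytotoxicity, read by MTT assay, with a stated time of 48 h; on this read-out higher numbers stand for weaker inhibition and lower numbers for stronger inhibition:
Compound 1 `O=S(=O)(c1ccc(-c2ccc3ncnc(Nc4ccc(OCc5cccc(F)c5)c(Cl)c4)c3c2)cc1)N1CCCCC1`: > 15000 nM, a limit
Compound 2 `O=S(=O)(c1cccc(-c2ccc3ncnc(Nc4ccc(OCc5cccc(F)c5)c(Cl)c4)c3c2)c1)N1CCCCC1`: > 15000 nM, a limit
Compound 3 `O=S(=O)(c1cccc(-c2ccc3ncnc(Nc4ccc(OCc5cccc(F)c5)c(Cl)c4)c3c2)c1)N1CCCC1`: > 15000 nM, a limit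

None of these three results is an exact number. Compound 1 sits at the limit of > 15000 nM in this assay, at which 3 of the 3 values shown sit. The compound to predict is compound 4 `CN1CCCN(S(=O)(=O)c2ccc(-c3ccc4ncnc(Nc5ccc(OCc6cccc(F)c6)c(Cl)c5)c4c3)cc2)CC1`, which has not yet been measured. It differs from compound 1 in a single group: 4-methyl-1,4-diazepan-1-yl in place of piperidin-1-yl on a sulfonyl sulfur. In plain terms, 4-methyl-1,4-diazepan-1-yl stands in place of piperidin-1-yl on a sulfonyl sulfur.

Within the data shown here, the one measured change at this place, a swap of one ring for another on the sulfonyl sulfur, is a step that the two limits leave unreadable from compound 2 to compound 3. It therefore offers no size to carry over, and the new group has not been tested in this series. The best guide is compound 1, whose result of > 15000 nM is a limit. In this assay, a small move towards lower numbers is expected, though compound 4 may well stay at the limit. The expected step is an at least 1.1-fold lower number from compound 1 to compound 4 (0.06 log units; that floor lies within the scatter). Compound 4 is estimated at 13000 nM, with an expected range of 5000 nM to 30000 nM.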

Compound 4, half-maximal inhibitory concentration: 1810 nM
For compound 4 the middle estimate is 7.2-fold (0.86 log units) above the measured one; measured number below the stated range.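

In this assay, putting 4-methyl-1,4-diazepan-1-yl in place of piperidin-1-yl on the sulfonyl sulfur gives an at least 8.2-fold lower number from compound 1 to compound 4 (0.91 log units; beyond the scatter), so the group at this place can clearly shift the read-out. Among these compounds, the only earlier swap at this sulfur, from compound 2 to compound 3, cannot be read, since both of its results are limits. Compound 4 therefore gives the first exact number in this set, while the other compounds remain at a shared ceiling: the limit of > 15000 nM in this assay, at which 3 of the 4 values shown sit.

This single swap changes the ring size, adds a ring nitrogen and adds a methyl all at once, and the compounds shown do not separate these changes. Going by these compounds, it remains open whether 4-methylpiperazin-1-yl or morpholin-4-yl on the same sulfur would also move the result away from the limit.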